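Adding One Fluoro Group to Compound 1

This account rests on a few compounds, and the source may have more. Where it says the series, first, only, none or still open, it means among the compounds named here.

compound 1 (`Clc1cc2nc(-c3cn(-c4ccccc4)nc3-c3ccccc3)[nH]c2cc1Cl`) gives 29700 nM as a measured number
compound 2 (`COc1ccc2[nH]c(-c3cn(-c4ccccc4)nc3-c3ccc(F)cc3)nc2c1`) gives > 50000 nM as a limit of the assay

Among the measured compounds shown here, only two compounds have been read in an ADME assay on HaCaT cells (Homo sapiens) for cytotoxicity, read by MTT assay, with a stated time of 48 h (on this read-out lower numbers stand for stronger inhibition and higher numbers for weaker inhibition), so far. For the measured compounds named here, compound 1 holds the only actual number among them, and the other reading is a limit.

Compound 3 (`Fc1ccc(-c2nn(-c3ccccc3)cc2-c2nc3cc(Cl)c(Cl)cc3[nH]2)cc1`) keeps the core of compound 1 and differs from it in one place (fluoro in place of hydrogen on an aromatic carbon). The new fluoro sits para to a large group, so that phenyl becomes 4-fluorophenyl.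

Going by the values given here, no two measured compounds differ in just one place, so no measured step shows how much such a change moves the value. In this assay a shift no larger than the usual scatter is expected, with neither direction favoured. Among the compounds with values here, the estimate therefore rests on compound 1 at 29700 nM as the one available number. The expected change is small, a 1.1-fold higher number from compound 1 to compound 3 (0.03 log units; within the scatter) as estimated here. A result reported only as a limit is also possible for compound 3. Compound 3 is estimated at 32000 nM with an expected range from 14000 nM to 50000 nM in this assay when it is measured.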

Compound 3, half-maximal inhibitory concentration: 44600 nM
Compound 3: the middle estimate sits 1.4-fold (0.14 log units) below what was measured; low and high end bracket the measured number.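

In this assay, among the compounds shown here, the exchange of hydrogen for fluoro on an aromatic carbon, which turns phenyl into 4-fluorophenyl, provides the first step between two measured compounds that differ in one place: a 1.5-fold higher number from compound 1 to compound 3 (0.18 log units; within the scatter). Because this step lies within the scatter, the pair gives no sign that fluoro at this position, para to a large group, changes the read-out, and a single heavy atom can be accepted here without a readable effect on the cytotoxicity number. Compound 3 still gives a measured number rather than a limit, so the step can be read at all, although the read-out has an upper end that one of the compounds shown has already reached: the limit of > 50000 nM in this assay, at which 1 of the 3 values shown sits.

What the compounds shown leave open is whether a different group at the same position, such as an amine, a carboxylic acid or a longer chain, would move the number beyond the scatter in either direction. They also leave open whether fluoro in place of hydrogen would give a similarly small step elsewhere on the core of compound 1.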